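Moving the sulfamoyl group: compound 2 to compound 3

A few compounds are considered here, and "the series" means these few. Any claim that something is new, unique, unknown or untested is made for them only; others in the source may bear on it.

Values measured so far in a functional assay on HUVEC cells (Homo sapiens) for inhibition (a lower number here means a stronger inhibitor, a higher number a weaker inhibitor), are these:
- compound 1 (`CN(c1ccc(NC(=O)Nc2ccccc2)cc1)c1ccnc(Nc2cccc(S(N)(=O)=O)c2)n1`) gives 2 nM
- compound 2 (`CN(c1ccc(NC(=O)Nc2cc(C(F)(F)F)ccc2F)cc1)c1ccnc(Nc2cccc(S(N)(=O)=O)c2)n1`) gives 10 nM

Of these two compounds, compound 2 has the higher number and is therefore the weaker inhibitor. The measured change is a 5.0-fold higher number from compound 1 to compound 2 (0.70 log units; beyond the scatter) and comes with 2-fluoro-5-(trifluoromethyl)phenyl in place of phenyl on an amide-type nitrogen.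

The next compound, compound 3 (`CN(c1ccc(NC(=O)Nc2cc(C(F)(F)F)ccc2F)cc1)c1ccnc(Nc2ccc(S(N)(=O)=O)cc2)n1`), differs from compound 2 by one change (4-sulfamoylphenyl in place of 3-sulfamoylphenyl on a nitrogen on an aromatic ring): 4-sulfamoylphenyl in place of 3-sulfamoylphenyl on a nitrogen on an aromatic ring. Within the data shown here, no measured compound carries the 4-sulfamoylphenyl group, and the single measured step lies at a different place. That modest step offers only a rough scale, not direct evidence for this change. A modest move towards a higher number in this assay is expected, though the direction is weakly supported. The estimated change is a 3.0-fold higher number from compound 2 to compound 3 (0.48 log units; beyond the scatter) as a working expectation. For compound 3 the estimated value is 30 nM with an expected range from 6 nM to 150 nM in this series.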

Compound 3, half-maximal inhibitory concentration: 8 nM
The estimate for compound 3 lay 3.8-fold (0.57 log units) above the measured number; low and high end bracket the measured number.
By their numbers in this assay, from the lowest: compound 1; then compounds 3 and 2 (each within the scatter of the next).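

In this assay, 4-sulfamoylphenyl in place of 3-sulfamoylphenyl on the nitrogen gives a 1.3-fold lower number from compound 2 to compound 3 (0.10 log units; within the scatter), so in this pair, which carries the 2-fluoro-5-(trifluoromethyl)phenyl group, the two placements of the sulfamoyl group cannot be told apart. Among these compounds, this is the first reading at this position, and it differs from the only earlier step, a 5.0-fold higher number from compound 1 to compound 2 (0.70 log units; beyond the scatter), which lies at another place in the molecule, on an amide-type nitrogen, and is beyond the scatter, whereas the new step is within it. Nothing measured on these compounds accounts for the two placements reading alike.

From the compounds shown here alone, the 4-sulfamoylphenyl group is seen here only with the 2-fluoro-5-(trifluoromethyl)phenyl group, so it remains open whether the placement is equally indifferent with the plain phenyl of compound 1, the compound with the lowest number so far. Also open, going by these compounds, is whether the sulfamoyl group itself matters at either placement, a question that a carboxylic acid, a methylsulfonyl group or a simple amine on the same ring would address.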